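Amide-side change from aryl to aminoalkyl in the series

The compounds below may be only part of what the source reports. "The series", "measured", "known", "first", "only" and "open" are said of these compounds alone.

The series shares a nitro-substituted heteroaromatic thioether core linked through a six-carbon chain to an ester and an amide. In an assay on isolated protein for inhibition of glutathione S-transferase Mu 2 (Homo sapiens), with a stated time of 10 min (on this read-out lower numbers stand for stronger inhibition and higher numbers for weaker inhibition), compound 1 `O=C(CCC(=O)OCCCCCCSc1ccc([N+](=O)[O-])c2nonc12)Nc1ccccc1Cl` gives 330 nM and compound 2 `O=C(CCC(=O)OCCCCCCSc1ccc([N+](=O)[O-])c2nonc12)Nc1ccc(F)c(Cl)c1` gives 470 nM. Going by the values given here, compound 2 stands alongside compound 1: the only measured step, a 1.4-fold higher number from compound 1 to compound 2 (0.15 log units; within the scatter), is within the scatter, so the two aryl amides are not separated on this read-out.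

Compound 3 `O=C(CCC(=O)OCCCCCCSc1ccc([N+](=O)[O-])c2nonc12)NCCN1CCCC1` differs from compound 2 by 2-(pyrrolidin-1-yl)ethyl in place of 3-chloro-4-fluorophenyl on an amide-type nitrogen. Among the compounds with values here, no measured step covers a change of this kind; the one step on hand, a 1.4-fold higher number from compound 1 to compound 2 (0.15 log units; within the scatter), exchanges one aryl group for another and says nothing about replacing the aryl group by an aminoalkyl chain. The expectation therefore rests on the unchanged core and linker alone, with no direction favoured beyond the scatter, and with a wide range to allow for the larger structural change. Compound 3 is estimated at 700 nM in this assay, within 200 nM to 3000 nM, which means an expected step of a 1.5-fold higher number from compound 2 to compound 3 (0.17 log units; within the scatter).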

Compound 3, half-maximal inhibitory concentration: 200 nM
Beside the measured number, compound 3's estimate is 3.5-fold (0.54 log units) above it; measured number inside the range.
By their numbers in this assay, from the lowest: compounds 3, 1 and 2 (each within the scatter of the next, the first and the last beyond it).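

In this assay, going by these compounds alone, the amide-type nitrogen does not need an aryl group to hold a number in this range: 2-(pyrrolidin-1-yl)ethyl in place of 3-chloro-4-fluorophenyl gives a 2.4-fold lower number from compound 2 to compound 3 (0.37 log units; beyond the scatter), the first step beyond the scatter, though a modest one. The gain does not extend to every aryl amide, since the same replacement for 2-chlorophenyl gives a 1.7-fold lower number from compound 1 to compound 3 (0.22 log units; within the scatter), which stays within the scatter, so compound 1 goes against any general claim that the aminoalkyl chain outperforms the aryl groups. Nothing available explains the step seen from the 3-chloro-4-fluorophenyl amide.

Still open, as far as these compounds go, is whether the step belongs to the ring nitrogen, the pyrrolidine ring or the ethyl chain; a piperidine or morpholine ring on the same chain, a propyl chain in place of ethyl, or a simple cyclopentylethyl group with no ring nitrogen would help to separate these. The compounds shown also leave the ester link untouched, so replacing it with an amide remains an open question for this series.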